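The compounds below may be only part of what the source reports. "The series", "measured", "known", "first", "only" and "open" are said of these compounds alone.

Measured so far:
compound 1, `Cc1nc(C(c2ccc(-c3ccc4cccc(F)c4c3)[nH]c2=O)C(C)C)[nH]c1C`: 0.0733 h
compound 2, `CC(C)[C@@H](C[C@H]1CCNC1=O)c1ccc(-c2ccc3cccc(F)c3c2)[nH]c1=O`: 0.507 h

In an ADME assay on microsomes from liver (Rattus norvegicus) for metabolic stability (on this read-out higher numbers stand for a longer-lived compound and lower numbers for a shorter-lived compound), compound 1 gives 0.0733 h, the lowest of the two numbers shown. Compound 2 gives 0.507 h, a gap beyond the usual scatter. Compound 3, `CC(C)C(/C=C1\CCNC1=O)c1ccc(-c2ccc3cccc(F)c3c2)[nH]c1=O`, is not yet measured. It differs from compound 1 in one place: a group of 7 heavy atoms (5 carbon, 1 nitrogen, 1 oxygen; one five-membered non-aromatic ring with 1 hetero atom) in place of a group of 7 heavy atoms (5 carbon, 2 nitrogen; one five-membered aromatic ring with 2 hetero atoms), on a saturated chain carbon bound to an aromatic carbon and a saturated chain carbon. Within the data shown here, no step between measured compounds covers this change, so its size can only be judged from the two values at hand. Compound 2, which also carries a five-membered non-aromatic ring with 1 hetero atom, gives the higher of the two numbers. For compound 3 an increase in this assay is therefore expected, a 4.1-fold higher number from compound 1 to compound 3 (0.61 log units; beyond the scatter), but with wide uncertainty since the ring in compound 3 is joined through a double bond rather than a saturated chain. Compound 3 is estimated at 0.3 h, with a range from 0.1 h to 0.9 h.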

Compound 3, half-life: 0.345 h
For compound 3 the middle estimate is 1.2-fold (0.06 log units) below the measured one, within the range that was stated.
By their numbers in this assay, from the lowest: compound 1; then compounds 3 and 2 (each within the scatter of the next).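

At the saturated chain carbon bound to an aromatic carbon and a saturated chain carbon, putting the five-membered non-aromatic ring with 1 hetero atom in place of 4,5-dimethyl-1H-imidazol-2-yl gives, in this assay, a 4.7-fold higher number from compound 1 to compound 3 (0.67 log units; beyond the scatter). Among these compounds, this is the first direct reading of a change at this position, and the group that enters matches the one that leaves in heavy atoms, hydrogen-bond donors, hydrogen-bond acceptors and net charge, so none of these counts separates the two compounds. No measurement shown bears on what lies behind this step.

As far as these compounds go, it remains open whether the step reflects the loss of 4,5-dimethyl-1H-imidazol-2-yl or the arrival of the new ring. From the compounds shown here alone, how a carboxylic acid, an amine or a longer chain at this carbon would stand in this assay also remains open.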